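A Nitro Group on the Furan of Compound 3

The compounds below may be only part of what the source reports. "The series", "measured", "known", "first", "only" and "open" are said of these compounds alone.

Compound 1 `CC1=CC[C@H]2[C@H](CC[C@]2(C)O)C(C)(C)[C@@H]1CC[C@H]1[C@]2(C)CC[C@H](OC(=O)c3ccc(F)cc3)C(C)(C)O[C@H]2CC[C@@]1(C)O`: 33500 nM
Compound 2 `CC1=CC[C@H]2[C@H](CC[C@]2(C)O)C(C)(C)[C@@H]1CC[C@H]1[C@]2(C)CC[C@H](OC(=O)c3ccccc3F)C(C)(C)O[C@H]2CC[C@@]1(C)O`: 11300 nM
Compound 3 `CC1=CC[C@H]2[C@H](CC[C@]2(C)O)C(C)(C)[C@@H]1CC[C@H]1[C@]2(C)CC[C@H](OC(=O)c3ccco3)C(C)(C)O[C@H]2CC[C@@]1(C)O`: 25700 nM

These values come from a functional assay on MCF7 cells (Homo sapiens) for antiproliferative activity, read by MTT assay, with a stated time of 72 h; a lower number here means a stronger inhibitor, a higher number a weaker inhibitor. The three compounds differ only in the group on the carbonyl carbon. Compound 3 cannot be separated from compound 1, with a 1.3-fold lower number from compound 1 to compound 3 (0.12 log units; within the scatter), but it clearly trails compound 2, with a 2.3-fold higher number from compound 2 to compound 3 (0.36 log units; beyond the scatter).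

Compound 4 `CC1=CC[C@H]2[C@H](CC[C@]2(C)O)C(C)(C)[C@@H]1CC[C@H]1[C@]2(C)CC[C@H](OC(=O)c3ccc([N+](=O)[O-])o3)C(C)(C)O[C@H]2CC[C@@]1(C)O` makes one change, furan-2-yl to 5-nitrofuran-2-yl: nitro in place of hydrogen on an aromatic carbon. Among the compounds with values here, no measured step adds a nitro. The closest evidence is the swaps on that carbonyl carbon, the largest being a 3.0-fold lower number from compound 1 to compound 2 (0.47 log units; beyond the scatter). A modest step toward a lower number is therefore expected in this assay, though its direction is only weakly supported. The expected step is a 2.1-fold lower number from compound 3 to compound 4 (0.33 log units; beyond the scatter). The estimate for compound 4 is 12000 nM, within an expected range of 4000 nM to 35000 nM.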

Compound 4, half-maximal inhibitory concentration: 21300 nM
Compound 4: the middle estimate sits 1.8-fold (0.25 log units) below what was measured; the measured number falls inside the stated range.
By their numbers in this assay, from the lowest: compounds 2, 4, 3 and 1 (each within the scatter of the next, the first and the last beyond it).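

In this assay, nitro on the furan, next to the ring oxygen, does not separate the compounds, with a 1.2-fold lower number from compound 3 to compound 4 (0.08 log units; within the scatter) in this one-place change. The 5-nitrofuran-2-yl group also leaves compound 4 within the scatter of both fluorophenyl compounds, with a 1.9-fold higher number from compound 2 to compound 4 (0.28 log units; within the scatter) and a 1.6-fold lower number from compound 1 to compound 4 (0.20 log units; within the scatter), so compound 4, unlike compound 3, is not set apart from compound 2. No measurement shown here explains this result. From the compounds shown here alone, whether an amine or a carboxylic acid at this furan carbon would separate from compound 3 remains open.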